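Methyl in Place of Hydrogen on the Shared Core

A few compounds are considered here, and "the series" means these few. Any claim that something is new, unique, unknown or untested is made for them only; others in the source may bear on it.

Measured compounds:
compound 1 `O=C(/C=C/c1cccc(Cl)c1)NNC(=O)c1ccc2c(c1)OCCO2` gives 3560 nM
compound 2 `O=C(/C=C/c1ccccc1)NNC(=O)c1ccc2c(c1)OCCO2` gives 550 nM
compound 3 `O=C(/C=C/c1ccc(F)cc1)NNC(=O)c1ccc2c(c1)OCCO2` gives 990 nM

Of the compounds shown here, three have been measured in a functional assay on cells (Cancer cell lines, Homo sapiens) for inhibition, read by MTT assay, with a stated time of 48 h; on this read-out higher numbers stand for weaker inhibition and lower numbers for stronger inhibition. Compound 2 gives the lowest number of the three; compound 3 lies nearest to it, and the step of a 1.8-fold higher number from compound 2 to compound 3 (0.26 log units; within the scatter) stays within the scatter, so nothing can be said about an order between compound 2 and compound 3. Compound 1 lies furthest away, and the step of a 6.5-fold lower number from compound 1 to compound 2 (0.81 log units; beyond the scatter) is beyond the scatter.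

Compound 4 `Cc1ccccc1/C=C/C(=O)NNC(=O)c1ccc2c(c1)OCCO2` has not yet been measured. It differs from compound 2 by methyl in place of hydrogen on an aromatic carbon. For the measured compounds named here, two measured steps bear on this change: a 1.8-fold higher number from compound 2 to compound 3 (0.26 log units; within the scatter), where fluoro in place of hydrogen on an aromatic carbon stayed within the scatter, and a 6.5-fold lower number from compound 1 to compound 2 (0.81 log units; beyond the scatter), where chloro in place of hydrogen gave a modest step. Going by the values given here, a methyl group on this ring in the place described has no direct precedent here. Compound 4 is therefore expected to give a number near that of compound 2, with a step of a 1.6-fold higher number from compound 2 to compound 4 (0.21 log units; within the scatter) that is estimated not to exceed the scatter, tending toward a higher number. The estimate for compound 4 is 900 nM, with a range from 350 nM to 2500 nM.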

Compound 4, half-maximal inhibitory concentration: 7710 nM
For compound 4 the middle estimate is 8.6-fold (0.93 log units) below the measured one; measured number outside the range, above it.
By their numbers in this assay, from the lowest: compounds 2 and 3 (each within the scatter of the next); then compound 1; then compound 4.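

In this assay, methyl on an aromatic carbon ortho to a large group brings a 14-fold higher number from compound 2 to compound 4 (1.15 log units; beyond the scatter), so a single added carbon at this place moves the number further than any earlier step shown. The 2-methylphenyl group also stands apart from the two other substituted phenyl groups, with a 7.8-fold higher number from compound 3 to compound 4 (0.89 log units; beyond the scatter) and a 2.2-fold higher number from compound 1 to compound 4 (0.34 log units; beyond the scatter), which makes compound 4 the weakest of the four, each of its steps being beyond the scatter. Nothing shown here accounts for the size of this step.

The compounds shown leave open whether the step belongs to this place on the ring or to methyl itself. A methoxy group or an amine on the same carbon, or methyl elsewhere on the ring, would bear on that question.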